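This account rests on a few compounds, and the source may have more. Where it says the series, first, only, none or still open, it means among the compounds named here.

Compound 1 `CCCCCCCCCCCC(=O)Nc1nnc(S[C@@H]2O[C@H](CO)[C@H](O)[C@H](O)[C@H]2O)s1` was tested in a functional assay on DU-145 cells (Homo sapiens) for cytotoxicity, read by MTT assay, with a stated time of 24 h (a higher number here means a weaker inhibitor, a lower number a stronger inhibitor), where compound 1 came out as "not active" (no number reported), so no number places it against the others. Two related compounds did give numbers: compound 2 `CCCCCCCC/C=C\CCCCCCCCCCCC(=O)Nc1nnc(S[C@@H]2O[C@H](COC(C)=O)[C@H](OC(C)=O)[C@H](OC(C)=O)[C@H]2OC(C)=O)s1` shows 28400 nM in this assay, and compound 3 `CCCCCCCCCCCCCCCC(=O)Nc1nnc(S[C@@H]2O[C@H](COC(C)=O)[C@H](OC(C)=O)[C@H](OC(C)=O)[C@H]2OC(C)=O)s1` shows 30100 nM. Among the measured compounds shown here, the step of a 1.1-fold higher number from compound 2 to compound 3 (0.03 log units; within the scatter) is the only measured change on the long chain, and it lies within the scatter. Compound 4 `C=CCCCCCCCCC(=O)Nc1nnc(S[C@@H]2O[C@H](CO)[C@H](O)[C@H](O)[C@H]2O)s1` differs from compound 1 by vinyl in place of propyl on a saturated chain carbon, eight bonds along the chain from a carbonyl carbon. This change, like the step between compound 2 and compound 3, sits on the chain, so no shift beyond the scatter is expected, and compound 4 may again give no number. If a number appears, compound 4 is expected around 60000 nM, ranging from 25000 nM to 150000 nM.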

Compound 4, half-maximal inhibitory concentration: "not active" (no number reported)
For compound 4 the study gives words and no number, and the estimate cannot be compared.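

Compound 1 and compound 4 both gave words and no number, so no step can be read between them, and no measurement shown here offers an explanation. From the compounds shown here alone, whether vinyl in place of propyl changes activity at all stays open.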